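The compounds below may be only part of what the source reports. "The series", "measured", "known", "first", "only" and "open" are said of these compounds alone.

Working notes on the series. Compound 3 `CCCc1ccc2c(c1)c(=O)c(C(=O)Nc1ccc(Oc3ncnc4[nH]cc(-c5ccccc5)c34)c(F)c1)c(C)n2C` sits highest of the two numbers at hand in an assay on isolated protein for inhibition of tyrosine-protein kinase receptor UFO (Homo sapiens), read by FRET and Z'-LYTE, with a stated time of 1.5 h; a lower number here means a stronger inhibitor, a higher number a weaker inhibitor; the nearest is compound 2 `CCc1ccc2c(c1)c(=O)c(C(=O)Nc1ccc(Oc3ncnc4[nH]cc(-c5ccccc5)c34)c(F)c1)c(C)n2C`, which in this assay gives 6 nM, against 61 nM for compound 3. Compound 1 `Cc1c(C(=O)Nc2ccc(Oc3ncnc4[nH]cc(-c5ccccc5)c34)c(F)c2)c(=O)c2cc(F)ccc2n1C` gives only a limit of the assay, > 10000 nM; of the three values shown, one sits at that limit (the limit of > 10000 nM in this assay, at which 1 of the 3 values shown sits). The step from compound 3 to compound 4 `COC(=O)c1ccc2c(c1)c(=O)c(C(=O)Nc1ccc(Oc3ncnc4[nH]cc(-c5ccccc5)c34)c(F)c1)c(C)n2C` is methoxycarbonyl in place of propyl on an aromatic carbon. Going by the values given here, two measured steps touch the same position: an at least 160-fold lower number from compound 1 to compound 3 (2.21 log units; beyond the scatter), and a 10-fold higher number from compound 2 to compound 3 (1.01 log units; beyond the scatter). Both point to this position being sensitive, with a small fluoro substituent at the limit and the two alkyl chains giving numbers well apart. None of them carries an ester or any other group with hydrogen-bond acceptors, so the direction for methoxycarbonyl is not fixed by the data. Compound 4 is therefore expected to give a modest, uncertain rise, a 2.5-fold higher number from compound 3 to compound 4 (0.39 log units; beyond the scatter), with an estimated value of 150 nM in a range from 20 nM to 2000 nM.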

Compound 4, half-maximal inhibitory concentration: > 10000 nM
Compound 4 gave a limit, no number (the forecaster's own chance of this, stated with the estimate: 10%); middle value at least 66-fold (1.82 log units) from the limit.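

Methoxycarbonyl removes the measurable inhibition seen with both alkyl chains at this position: replacing propyl gives an at least 160-fold higher number from compound 3 to compound 4 (2.21 log units; beyond the scatter), and replacing ethyl gives an at least 1600-fold higher number from compound 2 to compound 4 (3.22 log units; beyond the scatter). In this assay, compound 4 and compound 1 both give only a limit of the assay, so among the groups shown, only ethyl and propyl give a measurable number here: the limit of > 10000 nM in this assay, at which 2 of the 4 values shown sit. The step from compound 1 to compound 4 cannot be read.

On these data alone, whether the loss extends to other groups carrying oxygen remains open; a carboxylic acid, a primary amide or a methoxy group at this position would test that. Also open, as far as these compounds go, is whether a methyl group or a hydrogen keeps a measurable number, and whether a butyl chain raises the number further, as propyl does relative to ethyl.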